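A few compounds are considered here, and "the series" means these few. Any claim that something is new, unique, unknown or untested is made for them only; others in the source may bear on it.

Compound 1 `Cc1nc(-c2cccnc2)sc1-c1nnc(-c2ccc(Br)cc2)o1` gives > 100 ug/mL in an ADME assay on THP-1 cells (Homo sapiens) for cytotoxicity, read by MTT assay (a higher number here means that more compound is tolerated, a lower number that less compound is tolerated), which is a limit of the assay and not a number. Compound 2 `COc1ccccc1-c1nnc(-c2sc(-c3cccnc3)nc2C)o1` gives > 100 ug/mL in this assay, again a limit. Compound 3 `Cc1cccc(-c2nnc(-c3sc(-c4cccnc4)nc3C)o2)c1` gives > 100 ug/mL in this assay, also a limit.

Going by the values given here, compound 3 therefore stands where every value so far stands, as the limit of > 100 ug/mL in this assay, at which 3 of the 3 values shown sit, shows. Compound 4 `Cc1nc(-c2cccnc2)sc1-c1nnc(-c2ccc(O)cc2)o1` differs from compound 3 by 4-hydroxyphenyl in place of 3-methylphenyl on an aromatic carbon. Among the compounds with values here, no measured step can guide this change: a step that the two limits leave unreadable from compound 1 to compound 3 and a step that the two limits leave unreadable from compound 2 to compound 3 are both unreadable because each end is a limit, and a step that the two limits leave unreadable from compound 1 to compound 2 is likewise unreadable. Without any readable step, no shift beyond the scatter is expected, so compound 4 is estimated at 100 ug/mL, with a range from 50 ug/mL to 200 ug/mL, an expected step of a number no higher from compound 3 to compound 4 (the limit leaves the size open).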

Compound 4, half-maximal cytotoxic concentration: > 100 ug/mL
Compound 4 ended at the assay's limit; the forecaster's own chance of this, stated with the estimate: 80%; the middle value lies on the limit itself.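

Going by these compounds alone, no step among compound 1, compound 2, compound 3 and compound 4 can be read in this assay, since all four stand at one limit: the limit of > 100 ug/mL in this assay, at which 4 of the 4 values shown sit. As far as these compounds go, how far each compound lies past that limit stays open, as does whether swapping these aryl groups changes how much compound is tolerated.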